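Fluoro to chloro on one aromatic carbon

The source may hold more compounds than are shown below. What is called first, only, known or untested is meant among the compounds shown, and "the series" means these compounds.

Compound 1 `CC(Br)C(=O)Nc1ccc(Cl)c(C(=O)NC(N)=O)c1` gives 2550 nM
Compound 2 `Cc1ccc(NC(=O)CBr)cc1C(=O)NC(N)=O` gives 4760 nM
Compound 3 `NC(=O)NC(=O)c1cc(NC(=O)CBr)ccc1F` gives < 10 nM

In a functional assay on CCRF-CEM cells (Homo sapiens) for antiproliferative activity, read by trypan blue exclusion, with a stated time of 72 h (a higher number here means a weaker inhibitor, a lower number a stronger inhibitor), compound 3 stands at < 10 nM as a limit of the assay, not a number. Compound 4 `NC(=O)NC(=O)c1cc(NC(=O)CBr)ccc1Cl` has chloro in place of fluoro on an aromatic carbon para to a ((bromomethyl)carbonyl)amino group. Going by the values given here, the one measured step at that carbon (an at least 470-fold lower number from compound 2 to compound 3 (2.67 log units; beyond the scatter)) is large and beyond the scatter. Compound 1 also carries chloro there and gives 2550 nM in this assay but has a different side chain as well. From these two, a higher number beyond the scatter is expected for compound 4, though a smaller step than the measured one. The expected change is an at least 15-fold higher number from compound 3 to compound 4 (1.17 log units; beyond the scatter) in this assay on this estimate. For compound 4 the estimated value is 150 nM (expected range 10 nM to 3000 nM).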

Compound 4, half-maximal inhibitory concentration: 540 nM
For compound 4 the middle estimate is 3.6-fold (0.56 log units) below the measured one; low and high end bracket the measured number.
By their numbers in this assay, from the lowest: compound 4; then compounds 1 and 2 (each within the scatter of the next). At a limit, below all of these: compound 3.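

In this assay, the two halogens at this carbon are not interchangeable: chloro in place of fluoro gives an at least 54-fold higher number from compound 3 to compound 4 (1.73 log units; beyond the scatter). Chloro in place of methyl at the same carbon still gives an 8.8-fold lower number from compound 2 to compound 4 (0.95 log units; beyond the scatter), so the order of these three groups here is fluoro, chloro, methyl, from the lowest number. With chloro held in place, the side chain also counts, as hydrogen in place of methyl on the chain carbon bound to a bromine atom and a carbonyl carbon gives a 4.7-fold lower number from compound 1 to compound 4 (0.67 log units; beyond the scatter).

From the compounds shown here alone, compound 3 stands at a limit, so the full size of its step cannot be read: the limit of < 10 nM in this assay, at which 1 of the 4 values shown sits. Where hydrogen, a methoxy group or a nitrile at this carbon would fall remains open.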